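A third methoxy on the shared core

The source may hold more compounds than are shown below. What is called first, only, known or untested is meant among the compounds shown, and "the series" means these compounds.

Measured so far in an assay on cell membranes for inhibition of cytochrome P450 1A1 (Homo sapiens), read by fluorescence, using microsomes, with a stated time of 10 min; a higher number here means a weaker inhibitor, a lower number a stronger inhibitor:
compound 1 `COc1ccc(/C=C/C(=O)c2ccncc2)cc1OC` gives 380 nM
compound 2 `CCOc1cc(/C=C/C(=O)c2ccncc2)cc(OC)c1OC` gives 63 nM

Compound 1 stands at the higher of the two numbers. Compound 3 `COc1ccc(/C=C/C(=O)c2ccncc2)c(OC)c1OC` differs from compound 1 by methoxy in place of hydrogen on an aromatic carbon. Among the compounds with values here, the one measured step that bears on this, a 6.0-fold lower number from compound 1 to compound 2 (0.78 log units; beyond the scatter), is a modest one and adds an ethoxy at a different place on the same ring. A smaller change at another position is expected to move in the same direction, but less far, so for compound 3 an estimate of 150 nM (range 50 nM to 450 nM) is expected, a step of a 2.5-fold lower number from compound 1 to compound 3 (0.40 log units; beyond the scatter).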

Compound 3, half-maximal inhibitory concentration: 1410 nM
Estimate against measurement, compound 3: 9.4-fold (0.97 log units) below, outside the stated range (above it).
By their numbers in this assay, from the lowest: compound 2; then compound 1; then compound 3.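

In this assay, methoxy in place of hydrogen ortho to a large group gives a 3.7-fold higher number from compound 1 to compound 3 (0.57 log units; beyond the scatter), so here the added group weakens inhibition. The ethoxy change went the other way, with a 6.0-fold lower number from compound 1 to compound 2 (0.78 log units; beyond the scatter), which shows that adding a group to this ring does not by itself strengthen inhibition. Nothing available explains this reversal.

On these data alone, it remains open whether an amine or a hydroxyl at this same position would also raise the number. As far as these compounds go, it is also open whether the opposite outcome belongs to the ethoxy group or to its place.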